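Working notes on the series: compound 2 to compound 4

The source may hold more compounds than are shown below. What is called first, only, known or untested is meant among the compounds shown, and "the series" means these compounds.

The compounds are tested in a functional assay on CFPAC-1 cells (Homo sapiens) for antiproliferative activity, read by MTT assay, with a stated time of 72 h; on this read-out higher numbers stand for weaker inhibition and lower numbers for stronger inhibition. Compound 1 `O=C1O/C(=C\Cn2cc(-c3cc(F)cc(F)c3)nn2)C(OCc2ccccc2)=C1OCc1ccccc1` is recorded in this assay as "not active" (no number reported). For compound 3 `Cc1ccc(-c2cn(C/C=C3\OC(=O)C(OCc4ccccc4)=C3OCc3ccccc3)nn2)cc1` this assay gives > 100000 nM, which is a limit of the assay and not a number. That entry is the limit of > 100000 nM in this assay, at which 1 of the 3 values shown sits. Within the data shown here, compound 2 `O=C1O[C@H]([C@@H](O)Cn2cc(-c3cc(F)cc(F)c3)nn2)C(OCc2ccccc2)=C1OCc1ccccc1` gives 62400 nM in this assay and is the only compound of the three with a numeric value, the other two having no single number. Among the measured compounds shown here, no step between two measured compounds that differ in one place is available, so no measured change in this assay can be carried over.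

Compound 4 `O=C1O[C@H]([C@@H](O)Cn2cc(CNS(=O)(=O)c3ccc(Cl)cc3)nn2)C(OCc2ccccc2)=C1OCc1ccccc1` differs from compound 2 by (((4-chlorophenyl)sulfonyl)amino)methyl in place of 3,5-difluorophenyl on an aromatic carbon. The step from compound 2 to compound 4 in this assay is expected to be small, within the usual scatter or at most a modest move in either direction, as a 1.1-fold lower number from compound 2 to compound 4 (0.05 log units; within the scatter). Compound 4 is therefore estimated at 55000 nM, with a range from 15000 nM to 150000 nM, and a real chance that this assay reports only a limit for it.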

Compound 4, half-maximal inhibitory concentration: 38900 nM
Compound 4: middle estimate off by 1.4-fold (0.15 log units), on the high side; measured number inside the range.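

In this assay, among these compounds, the first measured step at this position, on an aromatic carbon of the five-membered aromatic ring with 3 nitrogen, is a 1.6-fold lower number from compound 2 to compound 4 (0.21 log units; within the scatter) for (((4-chlorophenyl)sulfonyl)amino)methyl in place of 3,5-difluorophenyl. The read-out therefore does not separate these two groups, although the entering group brings 1 hydrogen-bond donor and 2 hydrogen-bond acceptors where the leaving group has none. Both groups carry a six-membered aromatic ring of carbon only, and no measured property bears on this step.

From the compounds shown here alone, whether that ring is needed at this position stays open, since a simple amine, a carboxylic acid or a longer alkyl chain could test it. Going by these compounds, the share of the chlorine in the entering group also stays open.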